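This account rests on a few compounds, and the source may have more. Where it says the series, first, only, none or still open, it means among the compounds named here.

In an ADME assay on S9 fraction from liver (Homo sapiens) for metabolic stability, with a stated time of 60 min (a higher number here means that more of the compound is left, a lower number that less of the compound is left), three compounds with a shared core have been measured: compound 1 `CO[C@H]1CC[C@H](CN2C(=O)CNc3ncc(-c4ccc(-c5nc[nH]n5)nc4C)nc32)CC1` gives 90% and compound 2 `Cc1nc(-c2nc[nH]n2)ccc1-c1cnc2c(n1)N(CC1CCOCC1)C(=O)CN2` gives 100% and compound 3 `Cc1nc(-c2nc[nH]n2)ccc1-c1cnc2c(n1)N(C(C)C)C(=O)CN2` gives 99% on the same read-out. Compound 3 therefore stands within the scatter of both other compounds, and the numbers do not separate the three.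

Compound 4 `Cc1nc(-c2nc[nH]n2)ccc1-c1cnc2c(n1)N([C@H]1CC[C@H](O)CC1)C(=O)CN2` keeps the shared core and carries 4-hydroxycyclohexyl in place of isopropyl on an amide-type nitrogen in a ring.

All three measured steps involve substituents on this nitrogen. Isopropyl in place of (4-methoxycyclohexyl)methyl gave a number 9 percentage points higher from compound 1 to compound 3 (within the scatter) and isopropyl in place of (oxan-4-yl)methyl gave a number 1 percentage points lower from compound 2 to compound 3 (within the scatter). Oxan-4-yl in place of 4-methoxycyclohexyl gave a number 10 percentage points higher from compound 1 to compound 2 (within the scatter). None of these steps goes beyond the scatter in this assay. Among the measured compounds shown here, no measured compound has a hydroxy group or a ring bound directly to this nitrogen, so the data offer no direct precedent for compound 4.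

The expectation rests on these three small steps, and no step beyond the scatter is foreseen. The expected change is a number 6 percentage points lower from compound 3 to compound 4 (within the scatter) in this assay. Compound 4 is estimated at 93%, with an expected range from 80% to 100%.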

Compound 4, percent of the compound remaining: 97%
Compound 4: the middle estimate sits 4 percentage points below what was measured; measured number inside the range.
By their numbers in this assay, from the lowest: compounds 1, 4, 3 and 2 (each within the scatter of the next).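

In this assay, the amide-type nitrogen in a ring now carries a ring bound directly to it, and that ring bears a hydroxy group; the change from isopropyl to 4-hydroxycyclohexyl gives a number 2 percentage points lower from compound 3 to compound 4 (within the scatter). The same substituent stays within the scatter of both substituents attached through a saturated chain carbon, with a number 3 percentage points lower from compound 2 to compound 4 (within the scatter) and a number 7 percentage points higher from compound 1 to compound 4 (within the scatter), so neither the direct ring nor the added hydrogen-bond donor and acceptor separates compound 4 from the other three compounds on this read-out. No supporting measurement is available to explain these numbers.

All the steps among the four compounds lie within the scatter, so the compounds shown do not reveal any substituent on this nitrogen that clearly changes how much compound is left in this assay. Going by these compounds, it remains open whether an amine or a carboxylic acid in place of the hydroxy group on the cyclohexyl ring, or a longer alkyl chain on the nitrogen, would produce a step beyond the scatter.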